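Opening a ring nitrogen to a thiourea arm

The source may hold more compounds than are shown below. What is called first, only, known or untested is meant among the compounds shown, and "the series" means these compounds.

Measured compounds:
compound 1, `Cn1cccc1-c1cc(-c2ccc(Br)cc2)[nH]c(=O)c1C#N`, 77600 nM
compound 2, `COc1ccc(-c2cc(-c3cccn3C)c(C#N)c(=O)[nH]2)cc1OC`, 91200 nM
compound 3, `COc1ccc(-c2cc(-c3cccs3)[nH]c(=O)c2C#N)cc1`, a limit only

These three compounds share one core and were tested in a functional assay on IGROV-1 cells (Homo sapiens) for cytotoxicity, read by sulforhodamine B assay, with a stated time of 48 h; a lower number here means a stronger inhibitor of growth, a higher number a weaker inhibitor of growth. Compound 1 gives 77600 nM and compound 2 gives 91200 nM; compound 1 holds the lower of these two numbers, but the gap between them lies within the scatter, so the two cannot be told apart. For compound 3 the test reports a limit of > 100000 nM rather than a number; (the limit of > 100000 nM in this assay, at which 1 of the 3 values shown sits).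

Compound 4, `Cn1cccc1-c1cc(-c2ccc(Br)cc2)n(C(=S)Nc2ccc(F)cc2)c(=O)c1C#N`, has not yet been measured. It differs from compound 1 by a group of 10 heavy atoms (7 carbon, 1 nitrogen, 1 fluorine, 1 sulfur; one six-membered aromatic ring of carbon only) in place of a hydrogen atom, on an aromatic nitrogen. Among the measured compounds shown here, no measured pair shows what such a change does, so the expectation rests on compound 1 alone. In this assay a step from compound 1 to compound 4 of modest size toward a lower number is expected, of about a 1.7-fold lower number from compound 1 to compound 4 (0.24 log units; within the scatter), though a step within the scatter would not surprise. Compound 4 is therefore estimated at 45000 nM, with a range from 12000 nM to 150000 nM.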

Compound 4, concentration for 50% growth inhibition: 22900 nM
The estimate for compound 4 lay 2.0-fold (0.29 log units) above the measured number; the range from low to high includes it.
By their numbers in this assay, from the lowest: compound 4; then compounds 1 and 2 (each within the scatter of the next). At a limit, above all of these: compound 3.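

Replacing the hydrogen atom on the aromatic nitrogen with the thiourea arm gives a 3.4-fold lower number from compound 1 to compound 4 (0.53 log units; beyond the scatter). Among the compounds shown here, this nitrogen therefore accepts a group of this size with no loss of growth inhibition in this assay, something the earlier compounds could not show, since all of them keep the hydrogen atom there. Nothing measured here explains why the number falls.

This single pair cannot tell whether the whole arm or only part of it matters; an acetyl group on the same nitrogen, or the same arm with oxygen in place of sulfur, would help separate those parts. On these data alone, it also remains open whether the arm would lower the number in the same way on compound 2 or compound 3, which carry different groups on the shared core.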